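The source may hold more compounds than are shown below. What is called first, only, known or untested is meant among the compounds shown, and "the series" means these compounds.

Measured compounds:
- compound 1 `Brc1ccc(-c2nnc(SCCCN3CCN(c4nc5ccccc5o4)CC3)o2)cc1` with 115000 nM
- compound 2 `CC(C)(C)Oc1ccc(-c2nnc(SCCCN3CCN(c4nc5ccccc5o4)CC3)o2)cc1` with 94900 nM
- compound 3 `O=C(NCc1nnc(SCCCN2CCN(c3nc4ccccc4o3)CC2)o1)c1ccccc1` with 52700 nM

All three values come from a functional assay on MCF7 cells (Homo sapiens) for inhibition, read by MTT assay, with a stated time of 72 h; on this read-out lower numbers stand for stronger inhibition and higher numbers for weaker inhibition. Compound 1 stands at the upper end of these numbers, together with compound 2. The nearest comparison is a 1.2-fold lower number from compound 1 to compound 2 (0.08 log units; within the scatter), and the furthest is a 2.2-fold lower number from compound 1 to compound 3 (0.34 log units; beyond the scatter).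

The unmeasured compound 4 `Brc1ccc(-c2nnc(SCCCN3CCN(c4nc5ccccc5s4)CC3)o2)cc1` keeps the rest of compound 1 and changes one group, with 1,3-benzothiazol-2-yl in place of 1,3-benzoxazol-2-yl on an amine nitrogen in a ring.

For the measured compounds named here, no measured step touches this group. All three change the substituent on an aromatic carbon instead, so they bear on the question only indirectly, as a guide to how far the numbers have moved in this series. Besides the two steps above, there is a 1.8-fold lower number from compound 2 to compound 3 (0.26 log units; within the scatter). Going by the values given here, only the step to compound 3 exceeds the scatter, and it is modest, even though it replaces a whole 4-bromophenyl group. The new change keeps the counts of heavy atoms, rings and hydrogen-bond acceptors, yet its direction cannot be read from these data. No shift beyond the scatter is therefore expected in this assay.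

The expected step is a 1.2-fold lower number from compound 1 to compound 4 (0.06 log units; within the scatter).

For compound 4 the estimated value is 100000 nM, with an expected range from 45000 nM to 220000 nM.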

Compound 4, half-maximal inhibitory concentration: 96300 nM
Estimate against measurement, compound 4: 1.0-fold (0.02 log units) above; the range from low to high includes it.
By their numbers in this assay, from the lowest: compounds 3, 2, 4 and 1 (each within the scatter of the next, the first and the last beyond it).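

In this assay, for the compounds shown here, the move from 1,3-benzoxazol-2-yl to 1,3-benzothiazol-2-yl on the amine nitrogen in the ring gives a 1.2-fold lower number from compound 1 to compound 4 (0.08 log units; within the scatter) and provides the first measured step at this position, since the earlier steps all changed the substituent on an aromatic carbon. With the two groups matched in heavy atoms, rings and hydrogen-bond acceptors and differing by one ring oxygen against one ring sulfur, this exchange cannot be told apart from repeat measurement in this pair, at least with the 4-bromophenyl group kept in place. No accompanying measurement bears on why the number stays within the scatter.

The compounds shown leave open whether this position would respond to a group of a different kind, such as a plain phenyl, a pyridin-2-yl or an acetyl group on the same nitrogen, since the only two groups compared there are closely matched. They also leave open whether the same exchange would read alike with the 4-(tert-butoxy)phenyl or benzamidomethyl group in place of the 4-bromophenyl group.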